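Ester in place of a methoxy(methyl)amide on the side chain

A few compounds are considered here, and "the series" means these few. Any claim that something is new, unique, unknown or untested is made for them only; others in the source may bear on it.

Compound 1, `CCOC(=O)C[C@H]1[C@@H](O[Si](C)(C)C(C)(C)C)[C@H](n2cnc3c(NC(=O)Nc4ccccc4)ncnc32)O[C@@H]1COC(=O)NC`: 3.37 nM
Compound 2, `CNC(=O)NC[C@H]1O[C@@H](n2cnc3c(NC(=O)Nc4ccccc4)ncnc32)[C@H](O[Si](C)(C)C(C)(C)C)[C@@H]1CC(=O)N(C)OC`: 5.59 nM

In a functional assay on MCF7 cells (Homo sapiens) for antiproliferative activity (a lower number here means a stronger inhibitor of growth, a higher number a weaker inhibitor of growth), compound 2 gives 5.59 nM, and compound 1 gives 3.37 nM; the two numbers lie within the scatter of each other, so neither compound is separated from the other. Compound 3, `CCOC(=O)C[C@H]1[C@@H](O[Si](C)(C)C(C)(C)C)[C@H](n2cnc3c(NC(=O)Nc4ccccc4)ncnc32)O[C@@H]1CNC(=O)NC`, is not yet measured. It differs from compound 2 by ethoxy in place of methoxy(methyl)amino on a carbonyl carbon. Within the data shown here, with no measured step of this kind to draw on, the step from compound 2 to compound 3 in this assay is expected to stay within the scatter, as a 1.4-fold lower number from compound 2 to compound 3 (0.15 log units; within the scatter). Compound 3 is therefore estimated at 4 nM, in a range from 1.5 nM to 11 nM.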

Compound 3, concentration for 50% growth inhibition: 3.42 nM
Beside the measured number, compound 3's estimate is 1.2-fold (0.07 log units) above it; the measured number falls inside the stated range.
By their numbers in this assay, from the lowest: compounds 1, 3 and 2 (each within the scatter of the next).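

In this assay, ethoxy in place of methoxy(methyl)amino on a carbonyl carbon gives a 1.6-fold lower number from compound 2 to compound 3 (0.21 log units; within the scatter) and so does not separate the two side chains. With ethoxy in place, (methylcarbamoyl)amino in place of (methylcarbamoyl)oxy gives a 1.0-fold higher number from compound 1 to compound 3 (0.01 log units; within the scatter) and likewise separates nothing, so compound 3 links the earlier pair through two single changes, neither of which moves the number beyond the scatter. No measurement is available here that bears on these results. The compounds shown leave open whether a carboxylic acid or a longer chain on this carbonyl carbon would keep the number within the scatter. They also leave open how a simple amine there would read.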